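This account rests on a few compounds, and the source may have more. Where it says the series, first, only, none or still open, it means among the compounds named here.

Measured so far in a functional assay on NCI-H23 cells (Homo sapiens) for inhibition, read by sulforhodamine B assay, with a stated time of 48 h, tested at 10 uM; a higher number here means a weaker effect of the compound at the concentration tested, a lower number a stronger effect:
compound 1, `COc1cc2cc(Oc3ccc(NC(=O)Nc4ccccc4)cc3)c(C)nc2cc1OC`, gives 87.2%
compound 2, `COc1cc2cc(Oc3ccc(NC(=O)Nc4ccc(C)cc4)cc3)c(C)nc2cc1OC`, gives 95.6%
compound 3, `COc1cc2cc(Oc3ccc(NC(=O)Nc4cccc(C(F)(F)F)c4)cc3)c(C)nc2cc1OC`, gives 6.78%

Compound 3 stands lowest of the three numbers in this assay; compound 1 is the nearest, standing a number 80.4 percentage points lower from compound 1 to compound 3 (beyond the scatter), and compound 2 is the furthest, standing a number 88.8 percentage points lower from compound 2 to compound 3 (beyond the scatter). Compound 1 and compound 2 differ by a number 8.4 percentage points higher from compound 1 to compound 2 (within the scatter).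

Compound 4, `COc1cc2cc(Oc3ccc(NC(=O)Nc4ccc(Cl)c(Cl)c4)cc3)c(C)nc2cc1OC`, is not yet measured. It differs from compound 3 in one place: 3,4-dichlorophenyl in place of 3-(trifluoromethyl)phenyl on an amide-type nitrogen.

For the measured compounds named here, the steps that bear on this are the two that reach compound 3, a number 80.4 percentage points lower from compound 1 to compound 3 (beyond the scatter) and a number 88.8 percentage points lower from compound 2 to compound 3 (beyond the scatter), both large, and both tied to the arrival of the trifluoromethyl. Going by the values given here, compound 4 loses that group and gains two chlorines on the same ring; no measured pair shows what the 3,4-dichlorophenyl does, so the expectation is uncertain and wide. Compound 4 is expected to give 30%, within 5% to 85%, an expected step of a number 23.2 percentage points higher from compound 3 to compound 4 (beyond the scatter).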

Compound 4, a percentage reported as activity, at one concentration (the size of the read-out at that concentration, not a potency): 8.26%
Compound 4: the middle estimate sits 21.7 percentage points above what was measured; the range from low to high includes it.
By their numbers in this assay, from the lowest: compounds 3 and 4 (each within the scatter of the next); then compounds 1 and 2 (each within the scatter of the next).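

In this assay, replacing 3-(trifluoromethyl)phenyl with 3,4-dichlorophenyl on the amide-type nitrogen gives a number 1.5 percentage points higher from compound 3 to compound 4 (within the scatter), so at this position the low number is not tied to the trifluoromethyl group alone. The 3,4-dichlorophenyl compound also stands well apart from the other two, with a number 78.9 percentage points lower from compound 1 to compound 4 (beyond the scatter) and a number 87.3 percentage points lower from compound 2 to compound 4 (beyond the scatter), which places it with compound 3 and not with the unsubstituted phenyl of compound 1 or the 4-methylphenyl of compound 2.

Still open, going by these compounds, is whether a lone chlorine on this ring would give a number as low as the two chlorines do, and how a methoxy group, an amine or a carboxylic acid on the same ring would read. No measurement on hand accounts for why these two rings go with the low numbers.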